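A few compounds are considered here, and "the series" means these few. Any claim that something is new, unique, unknown or untested is made for them only; others in the source may bear on it.

Three compounds built on one shared core have been run in a functional assay on MDA-MB-231 cells (Homo sapiens) for inhibition, read by sulforhodamine B assay, with a stated time of 48 h, tested at 10 uM; a higher number here means more inhibition at the concentration tested (going by the name of the read-out), a lower number less inhibition. Compound 1 `c1ccc(-c2cn3ccnc3c(-c3ccc4ncn(C5CCCCC5)c4c3)n2)cc1` gives 41.5%, compound 2 `O=Cc1ccc(-c2cn3ccnc3c(-c3ccc4ncn(C5CCCCC5)c4c3)n2)cc1` gives 51.2%, and compound 3 `Fc1ccccc1-c1cn2ccnc2c(-c2ccc3ncn(C4CCCCC4)c3c2)n1` gives 21.3%. Compound 3 stands lowest of the three, with compound 1 nearest and compound 2 furthest. The step of a number 9.7 percentage points higher from compound 1 to compound 2 (within the scatter) lies within the scatter, whereas a number 20.2 percentage points lower from compound 1 to compound 3 (beyond the scatter) and a number 29.9 percentage points lower from compound 2 to compound 3 (beyond the scatter) are both modest losses beyond it. Compound 4 `FC(F)(F)c1cccc(-c2cn3ccnc3c(-c3ccc4ncn(C5CCCCC5)c4c3)n2)c1` is not yet measured; it differs from compound 3 in one place: 3-(trifluoromethyl)phenyl in place of 2-fluorophenyl on an aromatic carbon. For the measured compounds named here, no measured step exchanges one substituted ring for another of this kind, so the closest guidance is a number 20.2 percentage points lower from compound 1 to compound 3 (beyond the scatter), which shows that the 2-fluorophenyl of compound 3 carries a modest loss against compound 1. Since that group leaves, some recovery is expected, while the 3-(trifluoromethyl)phenyl that enters has no precedent among these compounds. Compound 4 is therefore expected to give 35%, between 15% and 55%. That expectation means a step of a number 13.7 percentage points higher from compound 3 to compound 4 (beyond the scatter), landing near the level of compound 1.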

Compound 4, a percentage reported as inhibition, at one concentration (the size of the read-out at that concentration, not a potency): 21.8%
Beside the measured number, compound 4's estimate is 13.2 percentage points above it, within the range that was stated.
By their numbers in this assay, from the lowest: compounds 3 and 4 (each within the scatter of the next); then compounds 1 and 2 (each within the scatter of the next).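

In this assay, 3-(trifluoromethyl)phenyl in place of 2-fluorophenyl at this position on the shared core gives a number 0.5 percentage points higher from compound 3 to compound 4 (within the scatter), so the two rings cannot be told apart here, although they differ in both the fluorine-bearing substituent and its place on the ring. Both compound 3 and compound 4 stand clear of the plain phenyl ring and the 4-formylphenyl ring: trifluoromethyl on the phenyl ring gives a number 19.7 percentage points lower from compound 1 to compound 4 (beyond the scatter), and the exchange of the formyl-bearing ring gives a number 29.4 percentage points lower from compound 2 to compound 4 (beyond the scatter) as its step. Nothing at hand explains why these two fluorine-bearing rings share one level.

The compounds shown leave open whether that level follows from the fluorine or from having any substituent at those places on the ring, since the formyl of compound 2 stands at a different place. They also leave open how a phenyl ring carrying an amine, a methoxy group or a carboxylic acid would behave at this position.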